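Benzyl on the ring nitrogen of compound 2: cytotoxicity

A few compounds are considered here, and "the series" means these few. Any claim that something is new, unique, unknown or untested is made for them only; others in the source may bear on it.

Measured compounds:
- compound 1, `O=C(OC1C=CC(n2ccc(=O)n(Cc3ccccc3)c2=O)C1)c1ccccc1`, > 25000 nM
- compound 2, `Cc1cc(=O)[nH]c(=O)n1C1C=CC(OC(=O)c2ccccc2)C1`, > 250000 nM

Both values come from an ADME assay on CCRF-CEM cells (Homo sapiens) for cytotoxicity, with a stated time of 3 days; a lower number here means that less compound is tolerated, a higher number that more compound is tolerated. For compound 1 the value > 25000 nM is a limit of the assay and not a number, so only the limit of > 25000 nM in this assay, at which 1 of the 2 values shown sits, is known. Compound 2 stands likewise at a limit: its value > 250000 nM is a limit of the assay, marking (the limit of > 250000 nM in this assay, at which 1 of the 2 values shown sits). The two compounds differ in more than one place, and as both values are limits, nothing can be said about an order between them.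

Compound 3, `Cc1cc(=O)n(Cc2ccccc2)c(=O)n1C1C=CC(OC(=O)c2ccccc2)C1`, has not been measured in this assay. It differs from compound 2 by benzyl in place of hydrogen on an aromatic nitrogen. Compound 1 also carries a benzyl on the aromatic nitrogen and sits at a limit, so a step in this assay from compound 2 to compound 3 of no more than the scatter, or a modest move toward less tolerated compound, is expected, and the step of an at least 2.5-fold lower number from compound 2 to compound 3 (0.39 log units; beyond the scatter) is the estimate. For compound 3 the expected value in this assay is 100000 nM, within 20000 nM to 300000 nM, with a fair chance that again only a limit is reported.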

Compound 3, half-maximal cytotoxic concentration: 34000 nM
Compound 3: the middle estimate sits 2.9-fold (0.47 log units) above what was measured; low and high end bracket the measured number.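

In this assay, within the data shown here, compound 3 gives 34000 nM, the first value that is a number and not a limit. Benzyl in place of hydrogen on this aromatic nitrogen, para to a methyl group, thus brings an at least 7.3-fold lower number from compound 2 to compound 3 (0.86 log units; beyond the scatter), and the true step may be larger, as compound 2 stands at a limit. The position therefore responds to substitution in this read-out: a group of one six-membered aromatic ring of carbon only, attached through its extra carbon, moves the series toward less tolerated compound, although this rests on a single pair.

Going by these compounds, whether the step belongs to benzyl in particular or to any replacement of that hydrogen stays open, and methyl, a longer chain such as butyl, or a chain ending in an amine or a carboxylic acid on the same nitrogen would separate the two readings. The part played by the methyl on the aromatic carbon also stays open, as the step between compound 1 and compound 3 cannot be read because compound 1 stands at a limit: the limit of > 25000 nM in this assay, at which 1 of the 3 values shown sits.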